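Demethylation of the ring amine in the shared core

A few compounds are considered here, and "the series" means these few. Any claim that something is new, unique, unknown or untested is made for them only; others in the source may bear on it.

Compound 1 `CN1C[C@H]2C=C(c3cccnc3)C[C@H](C2)C1` carries a methyl on the amine nitrogen of its core. In an in vitro functional assay on SH-EP1 cells for agonist activity at Neuronal acetylcholine receptor; alpha4/beta2 (Homo sapiens), read by FLIPR and calcium flux (on this read-out higher numbers stand for an effect only at larger amounts of compound and lower numbers for an effect already at smaller amounts), compound 1 gives > 10000 nM, which is a limit of the assay and not a number (the limit of > 10000 nM in this assay, at which 1 of the 3 values shown sits). Compound 4 `C1=C(c2cccnc2)C[C@H]2CNC[C@@H]1C2`, not yet measured, differs from compound 1 only by hydrogen in place of methyl on an amine nitrogen in a ring. Going by the values given here, no measured step covers this change: the single step recorded, a 1.6-fold higher number from compound 2 to compound 3 (0.20 log units; within the scatter), concerns fluoro in place of chloro on an aromatic carbon and does not bear on the amine nitrogen. What the numbers do show is that compound 2 `Clc1ccc(C2=CC3CNCC(C2)C3)cn1`, whose amine nitrogen bears hydrogen, gives 54 nM in this assay, and that compound 3 `Fc1ccc(C2=CC3CNCC(C2)C3)cn1`, likewise with hydrogen on that nitrogen, gives 85 nM. Both carry a halogen on the pyridine that compound 4 lacks, so their values set no direct expectation for compound 4. Compound 4 is therefore expected to give a number rather than a limit in this assay, estimated at 300 nM, between 50 nM and 2000 nM, a step of an at least 33-fold lower number from compound 1 to compound 4 (1.52 log units; beyond the scatter) whose size stays uncertain because compound 1 sits at the limit of > 10000 nM in this assay, at which 1 of the 3 values shown sits.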

Compound 4, half-maximal effective concentration: 2.3 nM
Estimate against measurement, compound 4: 130-fold (2.12 log units) above, outside the stated range (below it).
By their numbers in this assay, from the lowest: compound 4; then compounds 2 and 3 (each within the scatter of the next). At a limit, above all of these: compound 1.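

Going by these compounds alone, on the amine nitrogen in a ring of the shared core, hydrogen in place of methyl gives an at least 4300-fold lower number from compound 1 to compound 4 (3.63 log units; beyond the scatter) in this assay, and this is the first step that bears on this position. Compound 1 stands at a limit of the assay and not at a number, so this size is only a bound: the limit of > 10000 nM in this assay, at which 1 of the 4 values shown sits. The earlier step, a 1.6-fold higher number from compound 2 to compound 3 (0.20 log units; within the scatter), concerned only the halogen on an aromatic carbon and gave no reading of the amine nitrogen.

The compounds shown leave open whether methyl on this nitrogen has the same outcome when chloro or fluoro sits on the pyridine, as in compound 2 and compound 3. They also leave open how an ethyl group or a longer chain on this nitrogen would read in this assay.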